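Bromine Added to the Phenyl Ring of Compound 1

The source may hold more compounds than are shown below. What is called first, only, known or untested is meant among the compounds shown, and "the series" means these compounds.

Among the measured compounds shown here, compound 1 `c1ccc(-c2cn3ccnc3c(-c3ccc4ncn(C5CCCCC5)c4c3)n2)cc1` gives 34.5% in a functional assay on OVCAR-4 cells (Homo sapiens) for inhibition, read by sulforhodamine B assay, with a stated time of 48 h, tested at 10 uM (on this read-out higher numbers stand for more inhibition at the one concentration tested (going by the name of the read-out) and lower numbers for less inhibition), the higher of the two numbers measured so far. Compound 2 `c1ccc2c(-c3cn4ccnc4c(-c4ccc5ncn(C6CCCCC6)c5c4)n3)cccc2c1` gives 19.7%, and the step of a number 14.8 percentage points lower from compound 1 to compound 2 (beyond the scatter) lies beyond the scatter. Compound 3 `Brc1ccc(-c2cn3ccnc3c(-c3ccc4ncn(C5CCCCC5)c4c3)n2)cc1` differs from compound 1 by bromo in place of hydrogen on an aromatic carbon. For the measured compounds named here, no measured step covers this change: the one step known replaces phenyl with naphthalen-1-yl, a change of a different kind, so it gives little guidance. A step within the scatter is therefore expected, a number 0.5 percentage points higher from compound 1 to compound 3 (within the scatter). Compound 3 is estimated at 35%, with a range from 15% to 55%.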

Compound 3, a percentage reported as inhibition, at one concentration (the size of the read-out at that concentration, not a potency): 10.5%
The estimate for compound 3 lay 24.5 percentage points above the measured number; measured number outside the range, below it.
By their numbers in this assay, from the lowest: compounds 3 and 2 (each within the scatter of the next); then compound 1.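

A single bromine, on the phenyl ring and para to a large group, is enough to shift the result: in this assay the change gives a number 24 percentage points lower from compound 1 to compound 3 (beyond the scatter). Both changes to this ring therefore go with less inhibition than compound 1 shows, and the two changed compounds sit close, with a number 9.2 percentage points lower from compound 2 to compound 3 (within the scatter). Nothing available explains why the added bromine has this effect. Still open, on these data alone, is how a fluorine, a methoxy group or an amine at the same place would compare with bromo.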